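A few compounds are considered here, and "the series" means these few. Any claim that something is new, unique, unknown or untested is made for them only; others in the source may bear on it.

Measured in an ADME assay on J774.1 cells (Mus musculus) for cytotoxicity, read by resazurin assay, with a stated time of 48 h; a higher number here means a weaker inhibitor, a lower number a stronger inhibitor:
- Compound 1 `CCCCn1cc(C(=O)O)c(=O)c2cc(F)c(Cl)cc21`: > 100000 nM, a limit.
- Compound 2 `CCCn1cc(C(=O)NCc2ccccc2)c(=O)c2cc(F)c(N3CCC(C(N)=O)CC3)cc21`: 43700 nM.
- Compound 3 `CCCn1cc(C(=O)O)c(=O)c2cc(F)c(Cl)cc21`: > 100000 nM, a limit.

Compound 1 stands at the limit of > 100000 nM in this assay, at which 2 of the 3 values shown sit, so it offers no number to start from. Compound 4 `CCCCn1cc(C(=O)O)c(=O)c2cc(F)c(N3CCCCC3)cc21` comes from it by one change, piperidin-1-yl in place of chloro on an aromatic carbon, ortho to a fluoro group. Among the measured compounds shown here, the one measured step, a step that the two limits leave unreadable from compound 1 to compound 3, gives no size to carry over. Only compound 2 reaches a number, 43700 nM, so a modest move towards stronger inhibition in this assay is expected, if any can be read. The expected move is an at least 1.1-fold lower number from compound 1 to compound 4 (0.04 log units; that floor lies within the scatter). For compound 4 the estimate is 90000 nM, with an expected range of 35000 nM to 200000 nM.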

Compound 4, half-maximal inhibitory concentration: 93000 nM
For compound 4 the middle estimate is 1.0-fold (0.01 log units) below the measured one; measured number inside the range.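

Placing piperidin-1-yl in place of chloro on this aromatic carbon, ortho to a fluoro group, brings the core of compound 1 off the limit and to a readable number in this assay, with an at least 1.0-fold lower number from compound 1 to compound 4 (0.03 log units; that floor lies within the scatter). As far as these compounds go, the true size of that step stays open, because compound 1 rests only on a limit: the limit of > 100000 nM in this assay, at which 2 of the 4 values shown sit. The compounds shown leave open whether a morpholine ring or an open-chain amine such as dimethylamino on this same carbon would also give a readable number.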